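Swapping the thiocarbonyl substituent: an estimate for compound 4

The source may report more compounds than this note shows. Statements on the series, on what has been measured and on what is new or still open speak of the compounds shown alone.

Compound 1 `CCN1CCN(C(=S)SCC(=O)N(Cc2ccc(OC)cc2)c2cc(OC)c(OC)c(OC)c2)CC1`: 7700 nM
Compound 2 `COc1ccc(CN(C(=O)CSC(=S)N2CCc3ccccc32)c2cc(OC)c(OC)c(OC)c2)cc1`: 7710 nM
Compound 3 `COc1ccc(CN(C(=O)CSC(=S)N2CCc3cc(OC)ccc32)c2cc(OC)c(OC)c(OC)c2)cc1`: 9810 nM

These three values come from a functional assay on HCT-116 cells (Homo sapiens) for inhibition, read by CCK-8 assay, with a stated time of 48 h; a higher number here means a weaker inhibitor, a lower number a stronger inhibitor. Compound 3 cannot be told apart from the other two, since a 1.3-fold higher number from compound 2 to compound 3 (0.10 log units; within the scatter) and a 1.3-fold higher number from compound 1 to compound 3 (0.11 log units; within the scatter).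

The next compound to be measured is compound 4 `COc1ccc(CN(C(=O)CSC(=S)N2CCc3ccccc3C2)c2cc(OC)c(OC)c(OC)c2)cc1`. It differs from compound 3 at one place: 1,2,3,4-tetrahydroisoquinolin-2-yl in place of 5-methoxy-2,3-dihydro-1H-indol-1-yl on a thiocarbonyl carbon. In words, 1,2,3,4-tetrahydroisoquinolin-2-yl stands in place of 5-methoxy-2,3-dihydro-1H-indol-1-yl on a thiocarbonyl carbon.

Among the compounds with values here, three measured steps bear on this change. Two are swaps at that same carbon, a 1.0-fold higher number from compound 1 to compound 2 (0.00 log units; within the scatter) and a 1.3-fold higher number from compound 1 to compound 3 (0.11 log units; within the scatter), and the third is the methoxy addition, a 1.3-fold higher number from compound 2 to compound 3 (0.10 log units; within the scatter). All three stay within the scatter, so no step beyond the scatter is expected here, and no direction can be firmly predicted. Still, none of these compounds carries the entering group, so the expectation remains uncertain.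

The expected size of the change is small, with an estimated 1.2-fold lower number from compound 3 to compound 4 (0.06 log units; within the scatter). For compound 4 the estimated value is 8500 nM, with an expected range from 4200 nM to 17000 nM.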

Compound 4, half-maximal inhibitory concentration: 15900 nM
For compound 4 the middle estimate is 1.9-fold (0.27 log units) below the measured one; the measured number falls inside the stated range.
By their numbers in this assay, from the lowest: compounds 1, 2, 3 and 4 (each within the scatter of the next, the first and the last beyond it).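

In this assay, the thiocarbonyl carbon gives its first steps beyond the scatter: 1,2,3,4-tetrahydroisoquinolin-2-yl gives a modest weakening, with a 2.1-fold higher number from compound 2 to compound 4 (0.31 log units; beyond the scatter) and a 2.1-fold higher number from compound 1 to compound 4 (0.31 log units; beyond the scatter) as the two steps that show it. Set against 5-methoxy-2,3-dihydro-1H-indol-1-yl, the same group cannot be told apart, with a 1.6-fold higher number from compound 3 to compound 4 (0.21 log units; within the scatter) staying within the scatter, so this position tolerates some swaps only within a narrow band of values. Nothing measured here gives a reason for the weakening.

The compounds shown leave open how a simple open-chain amine such as diethylamino, or morpholin-4-yl, would behave on this same carbon. They also leave open whether a methoxy on the 1,2,3,4-tetrahydroisoquinolin-2-yl group would change the number at all.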